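Adding a chloro to the trifluoromethylphenyl urea

This account rests on a few compounds, and the source may have more. Where it says the series, first, only, none or still open, it means among the compounds named here.

Compound 1: `NS(=O)(=O)c1ccc(NC(=O)Nc2cccc(-c3nc(-c4ccc(NC(=O)c5cccnc5)cc4Cl)no3)c2)cc1`, a functional assay on MDA-MB-231 cells (Homo sapiens) for antiproliferative activity, read by MTT assay, with a stated time of 72 h; on this read-out higher numbers stand for weaker inhibition and lower numbers for stronger inhibition > 10000 nM.
Compound 2: `O=C(Nc1cccc(-c2nc(-c3ccc(NC(=O)c4cccnc4)cc3Cl)no2)c1)Nc1cccc(C(F)(F)F)c1`, in this assay compound 2 gives 1900 nM.

For compound 1 the value is a limit of the assay, not a number (the limit of > 10000 nM in this assay, at which 1 of the 2 values shown sits). Within the data shown here, compound 2 therefore stands as the only measured number here. Among the measured compounds shown here, the one measured step, an at least 5.2-fold lower number from compound 1 to compound 2 (0.72 log units; beyond the scatter), concerns the same ring that changes now, but swaps the whole group on the amide-type nitrogen. Compound 3 is `O=C(Nc1cccc(-c2nc(-c3ccc(NC(=O)c4cccnc4)cc3Cl)no2)c1)Nc1ccc(Cl)c(C(F)(F)F)c1`; it differs from compound 2 by chloro in place of hydrogen on an aromatic carbon. For the measured compounds named here, no measured step covers adding a chloro, so for compound 3 the expected step is a 1.3-fold lower number from compound 2 to compound 3 (0.10 log units; within the scatter), within the scatter. Compound 3 is estimated at 1500 nM, ranging from 500 nM to 4500 nM.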

Compound 3, half-maximal inhibitory concentration: 1900 nM
The estimate for compound 3 lay 1.3-fold (0.10 log units) below the measured number; the range from low to high includes it.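

In this assay, a chloro on this aromatic carbon, ortho to the trifluoromethyl group, is tolerated but brings no visible benefit: the result is no change at the digits printed from compound 2 to compound 3 (within the scatter). The advantage over the 4-sulfamoylphenyl group also remains with the chloro in place: an at least 5.2-fold lower number from compound 1 to compound 3 (0.72 log units; beyond the scatter). The value of compound 1 is a limit of the assay and not a number: the limit of > 10000 nM in this assay, at which 1 of the 3 values shown sits.

Going by these compounds, whether a different group at this position, such as an amine or a carboxylic acid, would shift the number remains open. So does whether the chloro would behave the same way without the neighbouring trifluoromethyl group.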